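This account rests on a few compounds, and the source may have more. Where it says the series, first, only, none or still open, it means among the compounds named here.

Of the compounds shown here, two have been read so far in a functional assay on the whole organism for antagonist activity, with Mus musculus as the target; on this read-out lower numbers stand for an effect already at smaller amounts and higher numbers for an effect only at larger amounts of compound. Compound 1 `COC(=O)N(C)CC#CCn1ccnc1` gives > 100 mg/kg, which is a limit of the assay and not a number. Compound 2 `CN(C)C(=O)N(C)CC#CCN1CCCC1` gives > 10 mg/kg, which is also only a limit. Within the data shown here, compound 2 therefore has no exact place on the scale, and no step between measured compounds is available. Compound 3 `CN(C)C(=O)N(C)CC#CCn1ccnc1` keeps the core of compound 2 but has 1H-imidazol-1-yl in place of pyrrolidin-1-yl on a saturated chain carbon bound to a triple-bonded carbon. The expectation rests on compound 1, which also carries 1H-imidazol-1-yl and shows the limit > 100 mg/kg. In this assay a shift towards larger doses is expected, with an estimated step that the limit leaves unreadable from compound 2 to compound 3. For compound 3 the estimated dose is 100 mg/kg, with an expected range from 20 mg/kg to 300 mg/kg.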

Compound 3, dose for half-maximal effect: > 100 mg/kg
Compound 3: no number, only a limit; the forecaster's own chance of this, stated with the estimate: 70%; the middle value lies on the limit itself.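

Compound 1, compound 2 and compound 3 all give only limits of the assay, so no step can be read from compound 2 to compound 3 or from compound 1 to compound 3. The compounds shown leave open whether 1H-imidazol-1-yl or pyrrolidin-1-yl gives the smaller dose in this assay.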